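The source may report more compounds than this note shows. Statements on the series, on what has been measured and on what is new or still open speak of the compounds shown alone.

Compound 1 `CC(C)n1nc(-c2cc(C3CCCCC3)on2)c2c(N)ncnc21`, compound 2 `CC(C)n1nc(-c2cc(C(C)(C)C)on2)c2c(N)ncnc21` and compound 3 `Nc1ncnc2c1c(-c1cc(C3CC3)on1)nn2C1CCCCC1` have been measured. In an assay on TT cells for inhibition of proto-oncogene tyrosine-protein kinase receptor Ret variant C634W (Homo sapiens), read by MTT assay, with a stated time of 10 days (a lower number here means a stronger inhibitor of growth, a higher number a weaker inhibitor of growth), compound 1 gives > 10000 nM, which is a limit of the assay rather than a number. In this assay compound 2 likewise gives > 10000 nM, again a limit. In this assay, within the data shown here, compound 3 gives 290 nM, the only result that is an actual number, so compound 3 stands as the one compound with a readable value. Compound 1 and compound 2 sit at the limit of > 10000 nM in this assay, at which 2 of the 3 values shown sit.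

Among the measured compounds shown here, the only measured step, a step that the two limits leave unreadable from compound 1 to compound 2, runs between two limits and cannot be sized; it also concerns a group on an aromatic carbon, not the ring nitrogen that changes here.

Compound 4 `CC(C)(O)Cn1nc(-c2cc(C3CC3)on2)c2c(N)ncnc21` arises from compound 3 by 2-hydroxy-2-methylpropyl in place of cyclohexyl on an aromatic nitrogen. For the measured compounds named here, no measured step bears on this change, so its direction cannot be read from the data; compound 1 and compound 2 carry a different group at that nitrogen and also differ elsewhere, and both are limits. The step of a 2.1-fold higher number from compound 3 to compound 4 (0.32 log units; beyond the scatter) is therefore expected to be a modest loss inside a wide range. For compound 4 the estimate in this assay is 600 nM, expected to fall between 150 nM and 3000 nM.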

Compound 4, concentration for 50% growth inhibition: 4250 nM
Beside the measured number, compound 4's estimate is 7.1-fold (0.85 log units) below it; the whole stated range lies below it.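

Replacing the cyclohexyl on the aromatic nitrogen with 2-hydroxy-2-methylpropyl gives a 15-fold higher number from compound 3 to compound 4 (1.17 log units; beyond the scatter) in this assay, a large loss of growth inhibition. This is the first readable step among the compounds shown, and it establishes that the group on this nitrogen strongly affects the result while the 5-cyclopropyl-1,2-oxazol-3-yl group stays the same. The change removes a ring and adds a hydrogen-bond donor and acceptor in one move, and nothing measured here gives a reason for the loss.

The compounds shown leave open whether the loss follows the removal of the ring or the arrival of the hydroxyl, a question that a plain 2-methylpropyl chain, without the hydroxyl, could help to separate. A 4-hydroxycyclohexyl group, which keeps the six-membered ring and adds a hydroxyl, or a piperidin-4-yl group, which places an amine in that ring, would show whether this nitrogen tolerates such atoms when the ring remains.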